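The compounds below may be only part of what the source reports. "The series", "measured", "known", "first", "only" and "open" are said of these compounds alone.

Of the compounds shown here, three built on a shared core have been tested in a functional assay on MCF7 cells (Homo sapiens) for cytotoxicity, read by MTT assay, with a stated time of 48 h; on this read-out higher numbers stand for weaker inhibition and lower numbers for stronger inhibition. Compound 2 `O=C(CSc1nc2ccc(NC(=O)c3ccccc3)cc2s1)NCc1ccccc1` gives 35600 nM in this assay. Compound 1 `O=C(CSc1nc2ccc(NC(=O)CCl)cc2s1)NCc1ccccc1` differs from it in one place, (chloromethyl in place of phenyl on a carbonyl carbon), and in this assay compound 1 gives 4200 nM, a step of an 8.5-fold lower number from compound 2 to compound 1 (0.93 log units; beyond the scatter). Compound 3 `COc1ccc(CNC(=O)CSc2nc3ccc(NC(=O)c4ccccc4)cc3s2)cc1` differs from compound 2 elsewhere, (methoxy in place of hydrogen on an aromatic carbon), and in this assay compound 3 gives 21200 nM, a step of a 1.7-fold lower number from compound 2 to compound 3 (0.23 log units; within the scatter).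

Compound 4 `COc1ccc(CNC(=O)CSc2nc3ccc(NC(=O)CCl)cc3s2)cc1` has not yet been measured. It differs from compound 3 by chloromethyl in place of phenyl on a carbonyl carbon. This is the same change as that from compound 2 to compound 1, and the surroundings of the place are the same in both, so it counts as the same change; it occurs twice among the four compounds. The cores of compound 3 and compound 4 differ from those of compound 2 and compound 1 by methoxy in place of hydrogen on an aromatic carbon. For compound 4 the expected step is an 8.5-fold lower number from compound 3 to compound 4 (0.93 log units; beyond the scatter), because the step of an 8.5-fold lower number from compound 2 to compound 1 (0.93 log units; beyond the scatter) was made by the same change on the neighbouring core. Compound 4 is therefore estimated at 2500 nM, with a likely range from 1000 nM to 6500 nM.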

Compound 4, half-maximal inhibitory concentration: 5100 nM
Compound 4: middle estimate off by 2.0-fold (0.31 log units), on the low side; the range from low to high includes it.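

Putting chloromethyl in place of phenyl on the carbonyl carbon again gives a lower number in this assay, a 4.2-fold lower number from compound 3 to compound 4 (0.62 log units; beyond the scatter), so on these two cores the change points the same way, and the two steps cannot be told apart in size: the same change on two cores in this assay, an 8.5-fold lower number (0.93 log units; beyond the scatter) from compound 2 to compound 1 and a 4.2-fold lower number (0.62 log units; beyond the scatter) from compound 3 to compound 4, 2.0-fold (0.31 log units) apart, within the scatter of two such steps. The methoxy group makes no difference that can be told from the scatter on either partner, with a 1.2-fold higher number from compound 1 to compound 4 (0.08 log units; within the scatter) here: the same change on two cores in this assay, a 1.7-fold lower number (0.23 log units; within the scatter) from compound 2 to compound 3 and a 1.2-fold higher number (0.08 log units; within the scatter) from compound 1 to compound 4, 2.0-fold (0.31 log units) apart, within the scatter of two such steps. This shows that the change carried over between two cores that differ only by that methoxy group, but it does not show that it would carry to more distant cores, and it says nothing about why chloromethyl gives the lower number.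

The compounds shown leave open whether the chlorine itself matters, which a plain methyl, a bromomethyl or an aminomethyl group on the same carbonyl carbon could test. Going by these compounds, it also remains open whether the carry-over would hold with a different group in place of methoxy, such as a carboxylic acid or an amine.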